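The source may report more compounds than this note shows. Statements on the series, on what has been measured and on what is new or still open speak of the compounds shown alone.

Measured so far:
compound 1 `CCn1c(C(=O)N[C@@H](C)C(=O)OC)ccc1C(CC)(CC)c1ccc(OCS(=O)(=O)c2ccccc2)c(C)c1` — 43700 nM
compound 2 `CCn1c(C(=O)N[C@H](CO)C(C)C)ccc1C(CC)(CC)c1ccc(OCS(=O)(=O)c2ccccc2)c(C)c1` — 25500 nM

Both were tested in a functional assay on MCF7 cells (Homo sapiens) for antiproliferative activity, read by MTT assay, with a stated time of 24 h; a lower number here means a stronger inhibitor, a higher number a weaker inhibitor. Compound 1 gives 43700 nM, the higher of the two numbers, and compound 2, with 25500 nM, stands nearest to it. Among the compounds with values here, the single measured step, a 1.7-fold lower number from compound 1 to compound 2 (0.23 log units; within the scatter), replaces the 1-(methoxycarbonyl)ethyl group on the amide-type nitrogen with a 1-(hydroxymethyl)-2-methylpropyl group, and the result stays within the scatter of the method.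

The unmeasured compound 3 `CCn1c(C(=O)N[C@@H](CO)CCCO)ccc1C(CC)(CC)c1ccc(OCS(=O)(=O)c2ccccc2)c(C)c1` differs from compound 1 at the same place:
a group of 7 heavy atoms (5 carbon, 2 oxygen; no ring) in place of a group of 6 heavy atoms (4 carbon, 2 oxygen; no ring), on an amide-type nitrogen
Within the data shown here, the entering group, like the one in compound 2, carries a hydroxymethyl in place of the methoxycarbonyl, so the step from compound 1 to compound 2 is the only measured step that bears on this change, and it was small. For this assay no change beyond the scatter is therefore expected, and the expected step is a 1.5-fold lower number from compound 1 to compound 3 (0.16 log units; within the scatter). Compound 3 is estimated at 30000 nM, with a range from 10000 nM to 90000 nM.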

Compound 3, half-maximal inhibitory concentration: 29600 nM
Estimate against measurement, compound 3: 1.0-fold (0.01 log units) above, and the stated range covers the measured number.
By their numbers in this assay, from the lowest: compounds 2, 3 and 1 (each within the scatter of the next).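

In this assay, the amide-type nitrogen now carries three different groups, and their numbers all lie within the scatter of one another: the new group gives a 1.5-fold lower number from compound 1 to compound 3 (0.17 log units; within the scatter), and set against the 1-(hydroxymethyl)-2-methylpropyl group it gives a 1.2-fold higher number from compound 2 to compound 3 (0.06 log units; within the scatter). The new group has 2 hydrogen-bond donors where 1-(methoxycarbonyl)ethyl has 0, and it is also one heavy atom larger, yet even this change in the printed counts comes with no step beyond the scatter, so for these three groups the choice of group at this place makes no measurable difference. No supporting measurement is available to explain why the numbers stay so close at this place.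

The compounds shown leave open whether a group of another kind on this nitrogen, such as an amine, a carboxylic acid or a phenyl ring, would give a step beyond the scatter. They also leave open whether the mirror-image form of any of these groups, or a change elsewhere on the shared core, would move the number further than the steps seen here.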